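The source may hold more compounds than are shown below. What is called first, only, known or untested is meant among the compounds shown, and "the series" means these compounds.

Measured compounds:
compound 1 `COc1cc2c(Oc3ccc(NC(=O)c4nn(-c5ccccc5OC(F)(F)F)c(=O)cc4C)cc3F)ccnc2cc1OCCCN1CCC(C)CC1` — 90 nM
compound 2 `COc1cc2c(Oc3ccc(NC(=O)c4nn(-c5ccccc5OC(F)(F)F)c(=O)cc4C)cc3F)ccnc2cc1OCCCN1CCN(C)CC1` — 130 nM

Of the compounds shown here, two have so far been measured in a functional assay on A549 cells (Homo sapiens) for inhibition, read by MTT assay, with a stated time of 72 h; a lower number here means a stronger inhibitor, a higher number a weaker inhibitor. Compound 1 `COc1cc2c(Oc3ccc(NC(=O)c4nn(-c5ccccc5OC(F)(F)F)c(=O)cc4C)cc3F)ccnc2cc1OCCCN1CCC(C)CC1` gives 90 nM. Compound 2 `COc1cc2c(Oc3ccc(NC(=O)c4nn(-c5ccccc5OC(F)(F)F)c(=O)cc4C)cc3F)ccnc2cc1OCCCN1CCN(C)CC1` gives 130 nM. Among the measured compounds shown here, these two numbers are not separated beyond the scatter: the only measured step, a 1.4-fold higher number from compound 1 to compound 2 (0.16 log units; within the scatter), concerns the amine at the end of the chain and says nothing about the rest of the molecule. Compound 1 therefore stands as one of two equivalent points rather than as a distinguished one.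

Compound 3 `COc1cc2c(Oc3ccc(NC(=O)c4nn(-c5ccc(Cl)cc5)c(=O)cc4C)cc3F)ccnc2cc1OCCCN1CCC(C)CC1` has not yet been measured. It differs from compound 1 in one place: 4-chlorophenyl in place of 2-(trifluoromethoxy)phenyl on an aromatic nitrogen. For the measured compounds named here, no measured step bears on this position, since the one step that exists changes a different part of the molecule. The account therefore has no measured basis for expecting a step beyond the scatter in this assay in either direction, and the expectation is accordingly broad. Compound 3 is estimated at 120 nM, with a range from 35 nM to 450 nM, which corresponds to an expected step of a 1.3-fold higher number from compound 1 to compound 3 (0.12 log units; within the scatter).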

Compound 3, half-maximal inhibitory concentration: 210 nM
For compound 3 the middle estimate is 1.8-fold (0.24 log units) below the measured one; the measured number falls inside the stated range.
By their numbers in this assay, from the lowest: compounds 1, 2 and 3 (each within the scatter of the next, the first and the last beyond it).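

In this assay, replacing 2-(trifluoromethoxy)phenyl with 4-chlorophenyl on the aromatic nitrogen gives a 2.3-fold higher number from compound 1 to compound 3 (0.37 log units; beyond the scatter). Among the compounds shown here, this is the first measured step at this position and the first to pass beyond the scatter, unlike the change of amine at the end of the chain, a 1.4-fold higher number from compound 1 to compound 2 (0.16 log units; within the scatter), so the group on this nitrogen can move the number, if only modestly here. The swap replaces a group of 11 heavy atoms with one of 7 and also changes both the substituent and its place on the phenyl ring, so this one step cannot separate those differences, and no evidence is available that bears on the result.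

The compounds shown leave open how an unsubstituted phenyl, a 2-chlorophenyl or a 4-(trifluoromethoxy)phenyl on this nitrogen would stand, and any of these would help to separate the identity of the substituent from its place on the ring. They also leave open whether the same step would appear with 4-methylpiperazin-1-yl at the end of the chain.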